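Swapping the Fluorophenyl Arm for a Methoxyphenyl

This account rests on a few compounds, and the source may have more. Where it says the series, first, only, none or still open, it means among the compounds named here.

Compound 1 `COc1cc(C(=O)c2sc3ccccc3c2-c2ccc(F)cc2)cc(OC)c1OC` belongs to a small set of three compounds built on one shared core, each tested in a functional assay on Jurkat cells (Homo sapiens) for antiproliferative activity, read by MTT assay, with a stated time of 72 h; a higher number here means a weaker inhibitor, a lower number a stronger inhibitor. Compound 1 gives 2300 nM. Compound 2 `COc1cc(C(=O)c2sc3ccccc3c2-c2ccc(Cl)cc2)cc(OC)c1OC` gives 3700 nM, and compound 3 `COc1ccc(-c2c(C(=O)c3cc(OC)c(OC)c(OC)c3)sc3ccccc23)cc1` gives 1600 nM. Compound 1 therefore holds the second highest of the three numbers: its nearest neighbour is compound 3, with a 1.4-fold lower number from compound 1 to compound 3 (0.16 log units; within the scatter), and its furthest is compound 2, with a 1.6-fold higher number from compound 1 to compound 2 (0.21 log units; within the scatter). Among the compounds with values here, both gaps fall within the scatter, so these three cannot be ranked against compound 1 on the numbers alone; only the step of a 2.3-fold lower number from compound 2 to compound 3 (0.36 log units; beyond the scatter) reaches beyond the scatter, and only modestly.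

Compound 4 `COc1ccccc1-c1c(C(=O)c2cc(OC)c(OC)c(OC)c2)sc2ccccc12` has not yet been measured. It differs from compound 1 in one place: 2-methoxyphenyl in place of 4-fluorophenyl on an aromatic carbon. Within the data shown here, the measured step that bears on this most closely is a 1.4-fold lower number from compound 1 to compound 3 (0.16 log units; within the scatter), where a methoxy likewise replaced a fluoro on an aromatic carbon, though here the methoxy enters as part of a 2-methoxyphenyl, a group none of the measured compounds carries. Since that step stayed within the scatter, no change beyond the scatter is expected in this assay for compound 4. Compound 4 is estimated at 2000 nM, with a range from 800 nM to 5000 nM. This estimate corresponds to an expected step of a 1.2-fold lower number from compound 1 to compound 4 (0.06 log units; within the scatter).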

Compound 4, half-maximal inhibitory concentration: 2900 nM
Compound 4: middle estimate off by 1.5-fold (0.16 log units), on the low side, within the range that was stated.
By their numbers in this assay, from the lowest: compounds 3, 1, 4 and 2 (each within the scatter of the next, the first and the last beyond it).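

Within the data shown here, this result is the first to show what happens when the methoxy group sits elsewhere on this aryl arm: in this assay, 2-methoxyphenyl in place of 4-methoxyphenyl gives a 1.8-fold higher number from compound 3 to compound 4 (0.26 log units; within the scatter), a step that stays within the scatter. The new arm also cannot be told apart from either halogen-bearing arm, with 2-methoxyphenyl in place of 4-fluorophenyl giving a 1.3-fold higher number from compound 1 to compound 4 (0.10 log units; within the scatter) and 2-methoxyphenyl in place of 4-chlorophenyl giving a 1.3-fold lower number from compound 2 to compound 4 (0.11 log units; within the scatter), so all three of the new steps stay within the scatter, even though compound 2 and compound 3 lie beyond the scatter of each other. Nothing shown here offers an explanation for these numbers.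

Going by these compounds, all four compounds carry a phenyl ring with a single fluoro, chloro or methoxy group at this place, so what an amine or a carboxylic acid on that ring would do remains open, as does the effect of a longer chain in place of the ring. On these data alone, whether these small steps would hold in any other cell line also remains open.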